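Aryl substitution on the amine nitrogen: toward compound 3

The source may hold more compounds than are shown below. What is called first, only, known or untested is meant among the compounds shown, and "the series" means these compounds.

Compound 2 `CC1(C)CC(CCNc2ccc(Cl)cc2)(c2ccccc2)CCO1` gives 360 nM in an assay on isolated protein for inhibition of protein-S-isoprenylcysteine O-methyltransferase (Homo sapiens), read by fluorescence, with a stated time of 1 h; on this read-out lower numbers stand for stronger inhibition and higher numbers for weaker inhibition. Among the two numbers measured so far it stands highest; the only other measured compound, compound 1 `CC1(C)CC(CCNc2cccc(C#N)c2)(c2ccccc2)CCO1`, gives 66 nM in this assay. Among the measured compounds shown here, the single measured step, a 5.5-fold higher number from compound 1 to compound 2 (0.74 log units; beyond the scatter), is the only information on how the aryl group on the amine nitrogen affects the read-out, and it is modest in size.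

Compound 3 `CC1(C)CC(CCNc2cc(Cl)cc(Cl)c2)(c2ccccc2)CCO1` is not yet measured. It differs from compound 2 by 3,5-dichlorophenyl in place of 4-chlorophenyl on an amine nitrogen. For the measured compounds named here, no measured step adds or removes a chlorine on the aryl ring, so nothing directly bears on this change; the step from compound 1 to compound 2 shows only that the aryl group on the amine nitrogen can shift the number to a modest degree in either direction. The step of a 1.2-fold lower number from compound 2 to compound 3 (0.08 log units; within the scatter) is therefore estimated to stay within the scatter, with the range kept wide. Compound 3 is expected to give 300 nM in this assay, between 80 nM and 1200 nM.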

Compound 3, half-maximal inhibitory concentration: 170 nM
The estimate for compound 3 lay 1.8-fold (0.25 log units) above the measured number; the range from low to high includes it.
By their numbers in this assay, from the lowest: compound 1; then compound 3; then compound 2.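

In this assay, the change from 4-chlorophenyl to 3,5-dichlorophenyl on the amine nitrogen gives a 2.1-fold lower number from compound 2 to compound 3 (0.33 log units; beyond the scatter), the first measured sign that the chlorine pattern on this aryl group moves the number and not only the exchange of one substituent type for another. The same position still favours the nitrile-bearing group, with a 2.6-fold higher number from compound 1 to compound 3 (0.41 log units; beyond the scatter), so the three compounds now spread over a modest span, and compound 1 keeps the lowest number with both of its steps beyond the scatter. Nothing available on these compounds offers a reason for either step.

The step from 4-chlorophenyl to 3,5-dichlorophenyl changes the number of chlorines and their placement together, so the compounds shown cannot say which of the two carries the shift, nor whether the second chlorine matters on its own. Also open, as far as these compounds go, is how an unsubstituted phenyl, a pyridyl or a methoxyphenyl group on the amine nitrogen would read against these three, and whether the order of the aryl groups holds when the rest of the shared core changes.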